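The source may hold more compounds than are shown below. What is called first, only, known or untested is meant among the compounds shown, and "the series" means these compounds.

- compound 1 `O=C(c1ccc(C(F)(F)F)c(F)c1)c1ccc2nc(NC(=O)C(F)(F)F)cn2c1` gives 56200 nM
- compound 2 `Cc1ccc(F)c(C(=O)c2ccc3nc(NC(=O)C(F)(F)F)cn3c2)c1` gives 57100 nM

In a functional assay on HCT-15 cells (Homo sapiens) for cytotoxicity, read by sulforhodamine B assay, with a stated time of 48 h (a lower number here means a stronger inhibitor, a higher number a weaker inhibitor), compound 2 gives 57100 nM and stands level with compound 1 at 56200 nM within the scatter of repeated measurements. The next compound is compound 3 `O=C(c1ccc2nc(NC(=O)C(F)(F)F)cn2c1)c1cc(C(F)(F)F)ccc1F` and its change from compound 2 is trifluoromethyl in place of methyl on an aromatic carbon. Among the measured compounds shown here, no two measured compounds differ in one place alone, so nothing yet shows what such a swap does, and no step beyond the scatter is expected in this assay here. The estimated step is a 1.1-fold lower number from compound 2 to compound 3 (0.06 log units; within the scatter) and this is a cautious expectation. For compound 3 the estimated value is 50000 nM with 22000 nM to 100000 nM as the expected range.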

Compound 3, half-maximal inhibitory concentration: 10500 nM
Compound 3: middle estimate off by 4.8-fold (0.68 log units), on the high side, outside the stated range (below it).
By their numbers in this assay, from the lowest: compound 3; then compounds 1 and 2 (each within the scatter of the next).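

In this assay, among the compounds shown here, the swap of methyl for trifluoromethyl on this aromatic carbon, meta to a large group and para to a fluoro group, gives a 5.4-fold lower number from compound 2 to compound 3 (0.74 log units; beyond the scatter) and is the first single change that can be read. It shows that the group at this place can move the number beyond the scatter. Nothing measured here accounts for the shift.

From the compounds shown here alone, how a chlorine atom, a methoxy group or an amine would fare at this carbon stays open. So does whether this swap would give a similar step at another place on the ring.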